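Changing the aryl group on a fused two-ring core

This account rests on a few compounds, and the source may have more. Where it says the series, first, only, none or still open, it means among the compounds named here.

For the measured compounds named here, compound 2 `CCCS(=O)(=O)Nc1ccc(F)c(C(=O)Nc2cnc3[nH]c(-c4ccc(Cl)c(Cl)c4)nc3c2)c1F` gives the higher of the two numbers so far in an ADME assay on Caco-2 cells (Homo sapiens) for permeability, in the apical to basolateral direction (a higher number here means that the compound crosses the layer faster, a lower number that the compound crosses the layer more slowly), at 2 10^-6 cm/s. Going by the values given here, its only measured neighbour, compound 1 `CCCS(=O)(=O)Nc1ccc(F)c(C(=O)Nc2cnc3[nH]cnc3c2)c1F`, carries hydrogen where compound 2 carries 3,4-dichlorophenyl; in this assay compound 1 gives 0.6 10^-6 cm/s, and the step of a 3.3-fold higher number from compound 1 to compound 2 (0.52 log units; beyond the scatter). Compound 3 `CCCS(=O)(=O)Nc1ccc(F)c(C(=O)Nc2cnc3[nH]c(-c4ccc(C(F)(F)F)cc4)nc3c2)c1F` is the next compound, and it differs from compound 2 in one place: 4-(trifluoromethyl)phenyl in place of 3,4-dichlorophenyl on an aromatic carbon. Among the compounds with values here, the one measured step bears only loosely on this change, since it added an aryl group to a bare ring, whereas here one aryl group replaces another of similar size. Without a measured exchange of this kind, the step is expected to stay small, as no change at the digits printed from compound 2 to compound 3 (within the scatter). Compound 3 is therefore estimated at 2 10^-6 cm/s in this assay, with a range from 0.8 10^-6 cm/s to 5 10^-6 cm/s.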

Compound 3, apparent permeability: 1 10^-6 cm/s
The estimate for compound 3 lay 2.0-fold (0.30 log units) above the measured number, and the stated range covers the measured number.
By their numbers in this assay, from the lowest: compounds 1, 3 and 2 (each within the scatter of the next, the first and the last beyond it).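

At this position, on the aromatic carbon between two ring nitrogen atoms, exchanging one aryl group for another leaves the number in this assay within the scatter (a 2.0-fold lower number from compound 2 to compound 3 (0.30 log units; within the scatter)). Compound 3 also cannot be told apart from compound 1, which carries hydrogen there (a 1.7-fold higher number from compound 1 to compound 3 (0.22 log units; within the scatter)), so the clear rise seen with 3,4-dichlorophenyl is not shown to extend to 4-(trifluoromethyl)phenyl, and compound 3 sits within the scatter of two compounds that are themselves beyond it. No measurement at hand explains these numbers.

Going by these compounds, it remains open whether a plain phenyl ring, with neither chlorine nor trifluoromethyl, would stand apart from compound 1. Also open, on these data alone, is how a group without an aryl ring, such as an amine or a longer alkyl chain, or a phenyl ring carrying a carboxylic acid, would behave at this carbon.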